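Second acetoxymethyl group on the core of compound 2

The compounds below may be only part of what the source reports. "The series", "measured", "known", "first", "only" and "open" are said of these compounds alone.

Measured so far in a functional assay on PC-3 cells (Homo sapiens) for cytotoxicity; a higher number here means a weaker inhibitor, a lower number a stronger inhibitor:
- compound 1 `COC(=O)C1C(c2oc(=O)c(CO)c(OC)c2CO)C(C(=O)OC)C1c1oc(=O)c(CO)c(OC)c1CO` gives > 50000 nM as a limit of the assay
- compound 2 `COC(=O)/C=C/c1oc(=O)c(COC(C)=O)c(OC)c1CO` gives 1090 nM

Going by the values given here, compound 2 at 1090 nM holds the only actual number in this small set. The entry for compound 1 is a limit of the assay. The next compound to read is compound 3 `COC(=O)/C=C/c1oc(=O)c(COC(C)=O)c(OC)c1COC(C)=O`. It differs from compound 2 by acetyl in place of hydrogen on an oxygen on a saturated carbon with acetyl in place of hydrogen on an oxygen on a saturated carbon, so that hydroxymethyl becomes acetoxymethyl. Among the compounds with values here, no measured pair shows this change, which leaves the expectation thinly supported. Compound 2 already carries one acetoxymethyl group and gives 1090 nM in this assay, so a second such group is not expected to shift the reading much. The step of a 1.1-fold higher number from compound 2 to compound 3 (0.04 log units; within the scatter) is expected to stay within the scatter, with no direction favoured. For compound 3 the estimated value is 1200 nM with an expected range from 300 nM to 5000 nM in this reading.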

Compound 3, half-maximal inhibitory concentration: 980 nM
For compound 3 the middle estimate is 1.2-fold (0.09 log units) above the measured one; measured number inside the range.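

In this assay, acetyl in place of hydrogen on the oxygen of this hydroxymethyl group gives a 1.1-fold lower number from compound 2 to compound 3 (0.05 log units; within the scatter). Going by these compounds alone, this is the first pair in the set that differs in one place, and it gives the first direct reading at this position: compound 2, with a free hydroxy, and compound 3, with a second acetoxymethyl group, cannot be told apart in this assay, so a free hydroxy here is not needed for a reading of this size. Nothing available on the compounds bears on why the change leaves the reading within the scatter.

Going by these compounds, what remains open is whether this flat result is particular to acetyl or holds for other groups at the same place, such as a longer acyl chain like butanoyl, an aminomethyl group, or a carboxylic acid in place of the hydroxymethyl. On these data alone, the other acetoxymethyl group of compound 3 also has no single-place partner here, so the reading with hydroxymethyl at that place on this core stays unknown.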